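Swapping isopropyl for ethoxy on a fused two-ring core

A few compounds are considered here, and "the series" means these few. Any claim that something is new, unique, unknown or untested is made for them only; others in the source may bear on it.

Of the compounds shown here, two have been measured in a functional assay on CHO cells for antagonist activity at Orexin receptor type 2 (Homo sapiens), read by FLIPR and calcium flux; on this read-out lower numbers stand for stronger inhibition and higher numbers for weaker inhibition. Compound 1 `CNC(=O)[C@@H](c1ccccc1)N1CCn2c(COC)nc(Cl)c2[C@@H]1CCc1ccc(C(F)(F)F)cc1` gives 25 nM in this assay. Compound 2 `CCc1nc(C(C)C)c2n1CCN([C@@H](C(=O)NC)c1ccccc1)C2CCc1ccc(C(F)(F)F)cc1` gives 2900 nM in this assay, the highest of the two numbers; its gap to compound 1 lies well beyond the scatter, so compound 2 is the weaker inhibitor of the pair. The change to compound 3 `CCOc1nc(CC)n2c1C(CCc1ccc(C(F)(F)F)cc1)N([C@@H](C(=O)NC)c1ccccc1)CC2` is ethoxy in place of isopropyl on an aromatic carbon. Among the compounds with values here, no measured pair shows this change alone, so its effect is not known from the data. Compound 1, the stronger inhibitor, carries a smaller group at that same place, which hints that a smaller substituent may be tolerated better. The step from compound 2 to compound 3 is therefore expected to be a moderate move toward stronger inhibition, a 4.1-fold lower number from compound 2 to compound 3 (0.62 log units; beyond the scatter). Compound 3 is expected to give about 700 nM in this assay, with a likely range from 120 nM to 3500 nM.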

Compound 3, half-maximal inhibitory concentration: 2750 nM
Estimate against measurement, compound 3: 3.9-fold (0.59 log units) below, and the stated range covers the measured number.
By their numbers in this assay, from the lowest: compound 1; then compounds 3 and 2 (each within the scatter of the next).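

In this assay, ethoxy in place of isopropyl on an aromatic carbon gives a 1.1-fold lower number from compound 2 to compound 3 (0.02 log units; within the scatter), so this exchange leaves the read-out within the usual scatter. At this place, next to the ring nitrogen, a group that brings in an oxygen and a hydrogen-bond acceptor thus gives a number that cannot be told apart from that of the all-carbon isopropyl group of the same heavy-atom count. Nothing measured here explains why the two groups match.

Going by these compounds, whether an amine, a hydroxyl or a longer chain such as butoxy would read the same at this place remains open. Compound 1 differs from compound 2 and compound 3 in more than one place, so these compounds do not show what a smaller group does here.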